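This account rests on a few compounds, and the source may have more. Where it says the series, first, only, none or still open, it means among the compounds named here.

Compound 3 `COc1cc(N)c(Cl)cc1NC(=O)C1CCN(Cc2ccc(C)c(C)c2)CC1` belongs to a set of three compounds that share one core and differ only in the group on a saturated chain carbon bound to an amine nitrogen in a ring. In a functional assay on the whole organism for antagonist activity, with Mus musculus as the target (on this read-out lower numbers stand for an effect already at smaller amounts and higher numbers for an effect only at larger amounts of compound), compound 3 gives > 8 mg/kg, which is a limit of the assay and not a number. Compound 1 `COc1cc(N)c(Cl)cc1NC(=O)C1CCN(CC2CCC2)CC1` gives > 10 mg/kg, likewise a limit. Compound 2 `COc1cc(N)c(Cl)cc1NC(=O)C1CCN(Cc2ccc([N+](=O)[O-])cc2)CC1` gives > 4 mg/kg, again a limit. With every value a limit, the steps a step that the two limits leave unreadable from compound 1 to compound 2, a step that the two limits leave unreadable from compound 1 to compound 3 and a step that the two limits leave unreadable from compound 2 to compound 3 cannot be read in size. Compound 4 `COc1cc(N)c(Cl)cc1NC(=O)C1CCN(CC2CCCCC2)CC1` differs from compound 3 by cyclohexyl in place of 3,4-dimethylphenyl on a saturated chain carbon bound to an amine nitrogen in a ring. Among the compounds with values here, no measured step bears on this change, so the step that the limit leaves unreadable from compound 3 to compound 4 is estimated with little footing. Compound 4 is expected to give about 15 mg/kg, within 4 mg/kg to 60 mg/kg, most probably again only a limit.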

Compound 4, dose for half-maximal effect: 2.9 mg/kg
Compound 4: middle estimate off by 5.2-fold (0.71 log units), on the high side; the measured number lies below the stated range.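

Within the data shown here, compound 4 is the first in this set to give a number and not a limit in this assay, so this position can hold a group that acts at a readable dose. Cyclohexyl in place of 3,4-dimethylphenyl gives an at least 2.7-fold lower number from compound 3 to compound 4 (0.44 log units; beyond the scatter), and cyclohexyl in place of cyclobutyl gives an at least 3.4-fold lower number from compound 1 to compound 4 (0.53 log units; beyond the scatter). Cyclohexyl in place of 4-nitrophenyl gives an at least 1.3-fold lower number from compound 2 to compound 4 (0.13 log units; that floor lies within the scatter), so this comparison remains unsettled.

The steps among compounds 1, 2 and 3 still cannot be read. Going by these compounds, whether cyclopentyl or unsubstituted phenyl on the same carbon would behave like cyclohexyl remains open.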